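Compound 3: An Amino Group on the Sulfonyl Sulfur

The compounds below may be only part of what the source reports. "The series", "measured", "known", "first", "only" and "open" are said of these compounds alone.

Of the compounds shown here, two sharing one core have been measured in an ADME assay on microsomes from liver (Mus musculus) for metabolic stability, read by LC-MS, with NADPH named in the record, with a stated time of 60 min, tested at 1 uM, in the absence of a further agent; on this read-out lower numbers stand for a less stable compound and higher numbers for a more stable compound. Compound 1 `COc1ccc(-c2c(C)nc3c(N4CC[C@@H](NC(=O)COc5ccccc5)C4)cc(C)nn23)cc1OC` gives > 95%, which is a limit of the assay and not an exact number. Compound 2 `COc1ccc(-c2c(C)nc3c(N4CC[C@@H](NS(=O)(=O)c5ccc(C(F)(F)F)cc5)C4)cc(C)nn23)cc1OC` gives > 95%, and this too is only a limit. That places compound 2 at the limit of > 95% in this assay, at which 2 of the 2 values shown sit. Compound 3 `COc1ccc(-c2c(C)nc3c(N4CC[C@@H](NS(N)(=O)=O)C4)cc(C)nn23)cc1OC` has not yet been measured. It differs from compound 2 by amino in place of 4-(trifluoromethyl)phenyl on a sulfonyl sulfur, with amino in place of 4-(trifluoromethyl)phenyl on a sulfonyl sulfur. Among the compounds with values here, no measured pair shows this change directly, so the expectation rests on compound 2 and its limit of > 95%. A step no larger than the usual scatter is expected, with a small fall possible. The estimated change is a number at least 5 percentage points lower from compound 2 to compound 3 (that floor lies within the scatter). Compound 3 is expected to read 90%, with an estimated range of 75% to 100%.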

Compound 3, percent of the compound remaining: > 95%
Compound 3: only a limit was reported (the forecaster's own chance of this, stated with the estimate: 45%); at least 5 percentage points between middle value and limit.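

In this assay compound 3 gives > 95%, which is a limit and not an exact number. Within the data shown here, compound 1 and compound 2 also sit at a limit, so no step to compound 3 can be read: the limit of > 95% in this assay, at which 3 of the 3 values shown sit. On these data alone, whether any of these structural changes alters the percent of compound remaining stays open.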